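The source may hold more compounds than are shown below. What is called first, only, known or untested is meant among the compounds shown, and "the series" means these compounds.

Among the compounds with values here, compound 1 `O=S(=O)(c1ccc(O)c2ncccc12)C1CCCC1` gives 1.8 L/kg in an ADME assay on the whole organism for pharmacokinetics, with Rattus norvegicus as the target (on this read-out higher numbers stand for wider distribution into tissues and lower numbers for narrower distribution), the lower of the two numbers known so far, while compound 2 `O=S(=O)(c1ccc(C(F)(F)F)cc1)c1cc(F)c(O)c2ncccc12` gives 3.8 L/kg in this assay. Compound 3 `O=S(=O)(c1cc(Cl)c(O)c2ncccc12)C1CCCC1` differs from compound 1 by a single change, (chloro in place of hydrogen on an aromatic carbon), set ortho to a hydroxy group on the shared core. Within the data shown here, no measured pair shows this change, so its effect is not known from the data. A small upward step in this assay, close to the usual scatter, is expected: a 1.3-fold higher number from compound 1 to compound 3 (0.11 log units; within the scatter). Compound 3 is therefore estimated at 2.3 L/kg, with a range of 1.2 L/kg to 4.5 L/kg.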

Compound 3, volume of distribution at steady state: 0.3 L/kg
Beside the measured number, compound 3's estimate is 7.7-fold (0.88 log units) above it, outside the stated range (below it).
By their numbers in this assay, from the lowest: compound 3; then compound 1; then compound 2.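

Within the data shown here, the first step between compounds that differ in one place shows that this position on the shared core is far from neutral in this assay: chloro in place of hydrogen, ortho to a hydroxy group, gives a 6.0-fold lower number from compound 1 to compound 3 (0.78 log units; beyond the scatter). A single added heavy atom at this aromatic carbon is thus enough to narrow distribution clearly. Nothing shown accounts for the drop.

Going by these compounds, it remains open whether a methyl group or an amine on this carbon would shift the number as far. Among these compounds, it is also open whether chloro here would act alike with another group in place of the one compound 1 carries on its sulfonyl.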